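The compounds below may be only part of what the source reports. "The series", "measured", "known", "first", "only" and "open" are said of these compounds alone.

Working notes on the series in an assay on isolated protein for inhibition of cytosolic endo-beta-N-acetylglucosaminidase (Homo sapiens), tested at 1000 uM; a higher number here means more inhibition at the concentration tested (going by the name of the read-out), a lower number less inhibition. Compound 1 `O=C(O)[C@@H]1NCC=C[C@@H]1O` gives 14% in this assay, and compound 3 `O=C(O)[C@@H]1NCC=C[C@H]1O` gives 14%. Compound 2 `O=C(O)[C@@H]1NC[C@@H](O)[C@@H](O)[C@H]1O` gives 26% in this assay, the highest of the three numbers and beyond the scatter from both compound 1 and compound 3. Within the data shown here, the one measured step between compounds that differ in a single place is no change at the digits printed from compound 1 to compound 3 (within the scatter), a step resting on (the fact that compounds 1 and 3 differ only in the configuration as drawn), so the sole inversion of one ring stereocentre recorded here left the read-out untouched.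

Compound 4 `O=C(O)[C@@H]1NC[C@H](O)[C@@H](O)[C@H]1O` is the next compound, differing from compound 2 as follows: the two compounds have the same atoms and bonds and differ only in configuration as drawn: 1 of 4 stereo elements differ; a stereocentre at a saturated ring carbon is drawn R in compound 2 and S in compound 4. Among the measured compounds shown here, the step from compound 1 to compound 3 is the only precedent that bears on this change and it stayed within the scatter, so in this assay a step of similar size is expected, a number 2 percentage points lower from compound 2 to compound 4 (within the scatter), with no clear direction. On that basis compound 4 is expected to give about 24% in this assay, estimated to fall between 10% and 40%.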

Compound 4, a percentage reported as inhibition, at one concentration (the size of the read-out at that concentration, not a potency): 42%
For compound 4 the middle estimate is 18 percentage points below the measured one, and the stated range ends below it.
By their numbers in this assay, from the lowest: compounds 1 and 3 (each within the scatter of the next); then compound 2; then compound 4.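

In this assay the inversion of one saturated ring carbon gives a number 16 percentage points higher from compound 2 to compound 4 (beyond the scatter). The earlier single inversion gave no change at the digits printed from compound 1 to compound 3 (within the scatter), so a change of configuration alone is not silent throughout the series, and the absence of an effect in that pair does not carry over to this one. The step can be assigned to this one stereocentre because nothing else separates the pair: the fact that compounds 2 and 4 differ only in the configuration as drawn

Still open, on these data alone, is how the remaining stereocentres of compound 4 contribute, and whether the gain from this inversion would survive a methyl ether in place of a ring hydroxyl or a methyl ester in place of the carboxylic acid. These are also single-concentration read-outs, so the size of the step says nothing about potency.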